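From methyl to ethynyl on compound 2

The source may report more compounds than this note shows. Statements on the series, on what has been measured and on what is new or still open speak of the compounds shown alone.

Of the compounds shown here, three have been measured so far: compound 1 (`CC1SC(c2cccc(C(=O)NCCCCc3ccccc3)c2)N(c2ccc(C3CC3)cc2)C1=O`), compound 2 (`Cc1cccc(N2C(=O)CSC2c2cccc(C(=O)NCCCCc3ccccc3)c2)c1`) and compound 3 (`Cc1ccnc(N2C(=O)CSC2c2cccc(C(=O)NCCCCn3cccn3)c2)c1`). In a physicochemical assay for solubility, read by turbidimetry, measured as kinetic solubility, at pH 6.8 (a lower number here means a less soluble compound, a higher number a more soluble compound), compound 1 gives 10000 nM and compound 2 gives 10000 nM with no difference beyond the scatter. These two together hold the lowest number of the three. Compound 3 reads 50000 nM in the same measurement, and that gap to compound 2 lies beyond the scatter.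

The next compound is compound 4 (`C#Cc1cccc(N2C(=O)CSC2c2cccc(C(=O)NCCCCc3ccccc3)c2)c1`). It carries ethynyl in place of methyl on an aromatic carbon, meta to a large group (ethynyl in place of methyl on an aromatic carbon), and the rest of compound 2 stays as it was. Among the compounds with values here, no measured pair shows this change on its own, so the data offer no direct precedent for it. The expectation therefore rests on compound 2 at 10000 nM as its starting point, with compound 1 at 10000 nM standing level with it. The expected step of no change at the digits printed from compound 2 to compound 4 (within the scatter) stays within the scatter and has no clear direction. The estimated value for compound 4 is 10000 nM (expected range 5000 nM to 20000 nM).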

Compound 4, solubility: 10000 nM
Compound 4: the middle estimate sits on the measured number at the digits printed, within the range that was stated.
By their numbers in this assay, from the lowest: compounds 1, 2 and 4 (each within the scatter of the next); then compound 3.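

In this assay, within the data shown here, the exchange of methyl for ethynyl on an aromatic carbon, meta to a large group, reads no change at the digits printed from compound 2 to compound 4 (within the scatter) and is the first step that can be read at a single place. Compounds 1, 2 and 3 differ from one another in more than one place, so they could say nothing about this position taken alone, whereas the pair of 3-methylphenyl and 3-ethynylphenyl now gives it one direct reading, and that reading lies within the scatter and has no direction. No independent measurement accompanies this pair, so the data offer no account of the result.

Among these compounds, what this single step leaves open is whether the same aromatic carbon stays as flat when it carries an amine, a carboxylic acid or a longer chain, since methyl and ethynyl, both built of carbon alone, are the only groups seen there so far. The higher number of compound 3 also remains unassigned, as compound 3 differs from compound 2 in more than one place and no single change can be credited with that gap.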